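Methoxy on the Phenyl of Compound 3

The source may hold more compounds than are shown below. What is called first, only, known or untested is meant among the compounds shown, and "the series" means these compounds.

Measured so far:
compound 1 `COc1ccc(-c2nnc(SC/C(=N/O)c3ccccc3)n2-c2ccccc2)cc1` — 58%
compound 2 `CCn1c(SCC(=O)c2ccccc2)nnc1-c1ccc(OC)cc1` — 53%
compound 3 `O=C(CSc1nnc(-c2ccccc2)n1-c1ccccc1)c1ccccc1` — 53%

Of the compounds shown here, three have been tested in a functional assay on the whole organism (strain albino) for inhibition, with Rattus norvegicus as the target, read by paw edema, with a stated time of 1 h, at a dose of 0.28 mmol/kg by the oral route; a lower number here means less inhibition, a higher number more inhibition at the dose given (going by the name of the read-out). Compound 3 stands level with compound 2 at the digits reported, and the two of them together give the lowest of the three numbers. The gap from compound 3 up to compound 1 is within the usual scatter of this assay, so none of the three can be called stronger or weaker than another on these numbers.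

Compound 4 `COc1ccc(-c2nnc(SCC(=O)c3ccccc3)n2-c2ccccc2)cc1` has not yet been measured in this assay. It differs from compound 3 in one place: methoxy in place of hydrogen on an aromatic carbon.

Going by the values given here, no step between two measured compounds isolates this change, so there is no direct guide to its size. Compound 1 and compound 2, which both carry the methoxy group, give numbers that sit within the scatter of compound 3, so no step beyond the scatter is expected here. For compound 4 the expected value in this assay is 55%, with a range from 44% to 66%. The expected step from compound 3 to compound 4 is thus a number 2 percentage points higher from compound 3 to compound 4 (within the scatter), a change no larger than the scatter.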

Compound 4, a percentage reported as inhibition, in the whole organism at one dose (the size of the read-out at that dose, not a potency): 52%
Compound 4: the middle estimate sits 3 percentage points above what was measured, and the stated range covers the measured number.
By their numbers in this assay, from the lowest: compounds 4, 2, 3 and 1 (each within the scatter of the next).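

In this assay the change from phenyl to 4-methoxyphenyl, para to a large group, can now be read directly as a number 1 percentage points lower from compound 3 to compound 4 (within the scatter) and thus leaves the read-out unmoved beyond the scatter at this place. The two other single changes that lead to compound 4 also stay within the scatter: phenyl in place of ethyl on the aromatic nitrogen gives a number 1 percentage points lower from compound 2 to compound 4 (within the scatter) and the group of 8 heavy atoms in place of the group of 9 heavy atoms, on the saturated chain carbon bound to a sulfur, gives a number 6 percentage points lower from compound 1 to compound 4 (within the scatter) as its step. Nothing measured here speaks to the reason for these results.

As far as these compounds go, whether an amine or a carboxylic acid in place of methoxy on this aromatic carbon would shift the number beyond the scatter remains open. So does the outcome of a longer chain in place of ethyl on the aromatic nitrogen.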